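The source may hold more compounds than are shown below. What is called first, only, known or untested is meant among the compounds shown, and "the series" means these compounds.

Measured in a functional assay on HT-1080 cells (Homo sapiens) for antiproliferative activity, read by sulforhodamine B assay, with a stated time of 48 h; a lower number here means a stronger inhibitor, a higher number a weaker inhibitor:
compound 1, `CCCCCC(=O)Nc1ccc(S(=O)(=O)Oc2ccccc2C(C)C)cc1`, gives 6300 nM
compound 2, `CCCCCC(=O)Nc1ccc(S(=O)(=O)Oc2ccccc2I)cc1`, gives 9600 nM
compound 3, `CC(C)c1ccccc1OS(=O)(=O)c1ccc(NC(=O)C(C)(C)C)cc1`, gives 11000 nM

Among these three numbers, compound 2 stands second highest. Its nearest neighbour is compound 3, and even the furthest, compound 1, lies within the scatter of it, so the three cannot be confidently told apart. Compound 4, `O=C(CCCCl)Nc1ccc(S(=O)(=O)Oc2ccccc2I)cc1`, is the next step from compound 2. The change is chloro in place of ethyl on a saturated chain carbon, three bonds along the chain from a carbonyl carbon; the rest of the molecule, including the iodo group on its aromatic carbon, stays as it is. Among the compounds with values here, no measured step alters this part of the chain in the same way. The closest comparison is the step of a 1.7-fold higher number from compound 1 to compound 3 (0.24 log units; within the scatter), which reshapes the acyl group attached to the carbonyl carbon and stays within the scatter. The step of a 1.5-fold higher number from compound 1 to compound 2 (0.18 log units; within the scatter) touches a different part of the molecule and also stays within the scatter. The one measured reshaping of the acyl group left the number essentially unchanged, and the same is expected here. Compound 4 is expected to show a step of no change at the digits printed from compound 2 to compound 4 (within the scatter), not beyond the scatter. Compound 4 is therefore estimated at 9600 nM, with a range from 3500 nM to 26000 nM.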

Compound 4, half-maximal inhibitory concentration: 12000 nM
Compound 4: middle estimate off by 1.3-fold (0.10 log units), on the low side; low and high end bracket the measured number.
By their numbers in this assay, from the lowest: compounds 1, 2, 3 and 4 (each within the scatter of the next).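

In this assay the end of the chain takes chloro in place of ethyl with a result of a 1.3-fold higher number from compound 2 to compound 4 (0.10 log units; within the scatter) and the two compounds cannot be told apart. The earlier compounds shown here reshaped the acyl group only with the isopropyl group in place, as tert-butyl in place of pentyl, whereas this step keeps the iodo group and puts a chlorine atom into the chain, so two quite different changes to the acyl group, on two different aromatic substituents, now both stay within the scatter. No measurement among these compounds bears on why the number holds here.

On these data alone, whether the same picture holds for a group of another kind at the end of the chain, such as an amine or a carboxylic acid, or for a chain longer than pentyl, remains open. Each of the four numbers also lies within the scatter of the next, so the compounds shown do not reveal which part of the molecule, if any, can move the number beyond the scatter.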